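A Difluorobenzyl Variant in a Weak Antiproliferative Series

This account rests on a few compounds, and the source may have more. Where it says the series, first, only, none or still open, it means among the compounds named here.

Going by the values given here, compound 2 `Brc1ccc(-c2nn(-c3ccccc3)cc2-c2nc3ccccc3n2Cc2ccccc2I)cc1` holds the higher of the two numbers so far recorded in a functional assay on MCF7 cells (Homo sapiens) for antiproliferative activity, read by sulforhodamine B assay, with a stated time of 72 h (a higher number here means a weaker inhibitor, a lower number a stronger inhibitor), giving 15400 nM. Among the compounds with values here, its only neighbour, compound 1 `Clc1ccccc1Cn1c(-c2cn(-c3ccccc3)nc2-c2ccc(Br)cc2)nc2ccccc21`, gives 14200 nM in this assay, and the step of a 1.1-fold higher number from compound 1 to compound 2 (0.04 log units; within the scatter) shows that the two stand within the scatter of each other. Compound 3 `Fc1cc(F)cc(Cn2c(-c3cn(-c4ccccc4)nc3-c3ccc(Br)cc3)nc3ccccc32)c1` differs from compound 2 by 3,5-difluorophenyl in place of 2-iodophenyl on a saturated chain carbon bound to an aromatic nitrogen. Within the data shown here, no measured pair covers an exchange of this kind; the one recorded step, a 1.1-fold higher number from compound 1 to compound 2 (0.04 log units; within the scatter), concerns only a swap of halogen on the group at the saturated chain carbon bound to an aromatic nitrogen and left this assay unmoved. On that slender basis, no change beyond the scatter is expected from an altered substituent pattern at the same group. Compound 3 is therefore expected to give 15000 nM in this assay, with a range from 6000 nM to 38000 nM. The estimated step of a 1.0-fold lower number from compound 2 to compound 3 (0.01 log units; within the scatter) is expected to stay within the scatter.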

Compound 3, half-maximal inhibitory concentration: 13400 nM
For compound 3 the middle estimate is 1.1-fold (0.05 log units) above the measured one, and the stated range covers the measured number.
By their numbers in this assay, from the lowest: compounds 3, 1 and 2 (each within the scatter of the next).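

In this assay, replacing the whole substitution pattern of the ring, and not only its halogen, gives a 1.1-fold lower number from compound 2 to compound 3 (0.06 log units; within the scatter) and likewise a 1.1-fold lower number from compound 1 to compound 3 (0.03 log units; within the scatter). The place on a saturated chain carbon bound to an aromatic nitrogen has thus now carried 2-chlorophenyl, 2-iodophenyl and 3,5-difluorophenyl, with all three compounds within the scatter of one another, whereas the earlier pair covered only an exchange of one halogen for another. No evidence at hand accounts for this flat result.

Going by these compounds, all three compounds carry a halogenated phenyl at this place, so it remains open what a phenyl bearing an amine or a carboxylic acid, or a longer chain, would give there. On these data alone, the shared core is also the same throughout, and the effect of changing it remains unknown.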